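Dropping one chloro from the core: expected loss of potency

This account rests on a few compounds, and the source may have more. Where it says the series, first, only, none or still open, it means among the compounds named here.

Measured so far:
compound 1 `ClCc1ccc(Cn2cnc3c(Cl)ncnc32)cc1` — 38900 nM
compound 2 `ClCc1ccccc1Cn1cnc2c(Cl)nc(Cl)nc21` — 5880 nM

In a functional assay on EKVX cells (Homo sapiens) for cytotoxicity, read by sulforhodamine B assay, with a stated time of 48 h (a lower number here means that less compound is tolerated, a higher number that more compound is tolerated), compound 2 gives 5880 nM, the lowest of the two numbers available, and compound 1 sits at 38900 nM, a gap beyond the usual scatter. Compound 3 `ClCc1ccccc1Cn1cnc2c(Cl)ncnc21` has not yet been measured. It differs from compound 2 in one place: hydrogen in place of chloro on an aromatic carbon. Among the compounds with values here, no measured pair shows this exact change, so the size of the step is uncertain. Still, compound 1, which also carries a single chloro on its core, gives 38900 nM, which points toward a higher number for compound 3. Compound 3 is therefore expected to come out at 16000 nM, with a plausible range from 5000 nM to 50000 nM. The step from compound 2 to compound 3 is estimated at a 2.7-fold higher number from compound 2 to compound 3 (0.43 log units; beyond the scatter), a rise beyond the scatter.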

Compound 3, concentration lethal to 50% of the cells: 37200 nM
For compound 3 the middle estimate is 2.3-fold (0.37 log units) below the measured one; the measured number falls inside the stated range.
By their numbers in this assay, from the lowest: compound 2; then compounds 3 and 1 (each within the scatter of the next).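

In this assay, replacing chloro with hydrogen on the aromatic carbon between two ring nitrogen atoms gives a 6.3-fold higher number from compound 2 to compound 3 (0.80 log units; beyond the scatter), so the cells tolerate more of the compound once this chloro is gone. Within the data shown here, because this pair differs in this one place only, it gives the first direct reading of the position and shows that the chloro here contributes to the cell-killing effect seen in this test. Nothing available explains the direction or size of this step.

The compounds shown compare only chloro and hydrogen at this position, so they leave open how an amine or a methoxy group there would behave. Resting on a single pair in one type of cell, they also leave open whether the same step would appear in other compounds or other cells.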